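The source may report more compounds than this note shows. Statements on the series, on what has been measured and on what is new or still open speak of the compounds shown alone.

In a functional assay on MC-38 cells (Mus musculus) for antiproliferative activity, read by CCK-8 assay, with a stated time of 48 h (on this read-out higher numbers stand for weaker inhibition and lower numbers for stronger inhibition), compound 3 (`COc1ccc(/C=C\c2cc(OC)c(OC)c(OC)c2)cc1OCc1ccc(CN2CC[C@@H](C(=O)O)C2)cc1`) gives 6300 nM as the higher of the two exact numbers in the series. Compound 2 (`COc1ccc(/C=C\c2cc(OC)c(OC)c(OC)c2)cc1OCc1ccc(CNCCO)cc1`) gives 1200 nM as the other, and the gap between them is a 5.3-fold higher number from compound 2 to compound 3 (0.72 log units; beyond the scatter) on this read-out. Compound 1 (`COc1ccc(/C=C\c2cc(OC)c(OC)c(OC)c2)cc1OCc1ccc(CNC(C)(C)C(=O)O)cc1`) stands at > 10000 nM as a limit only.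

The change to compound 4 (`COc1ccc(/C=C\c2cc(OC)c(OC)c(OC)c2)cc1OCc1ccc(CN2CCCCC2C(=O)NCCN)cc1`) is 2-((2-aminoethyl)carbamoyl)piperidin-1-yl in place of 3-carboxypyrrolidin-1-yl on a saturated chain carbon bound to an aromatic carbon. Within the data shown here, compound 2, the one measured member without a carboxy group, lies lower than both others, and the second step showing this is an at least 8.3-fold lower number from compound 1 to compound 2 (0.92 log units; beyond the scatter) in the series. The remaining step (an at least 1.5-fold lower number from compound 1 to compound 3 (0.20 log units; that floor lies within the scatter)) adds little. Compound 4 also lacks a carboxy group, but its entering group is otherwise untested. Compound 2 at 1200 nM is therefore the guide, and a modest fall is expected in this assay for this change. The estimated step is a 4.2-fold lower number from compound 3 to compound 4 (0.62 log units; beyond the scatter) in size. Compound 4 is estimated at 1500 nM with an expected range of 300 nM to 7000 nM for its value.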

Compound 4, half-maximal inhibitory concentration: > 10000 nM
Compound 4 ended at the assay's limit; the forecaster's own chance of this, stated with the estimate: 5%; middle value at least 6.6-fold (0.82 log units) from the limit.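

In this assay compound 4 gives > 10000 nM, which is a limit of the assay and not a number. The entering 2-((2-aminoethyl)carbamoyl)piperidin-1-yl group gives an at least 8.3-fold higher number from compound 2 to compound 4 (0.92 log units; beyond the scatter), whereas the comparison with the carboxylic acid gives an at least 1.5-fold higher number from compound 3 to compound 4 (0.20 log units; that floor lies within the scatter). The lower number of compound 2 therefore does not follow from the absence of a carboxy group alone, as compound 4 also lacks one and goes against that reading of compound 1, compound 2 and compound 3.

As far as these compounds go, the step from compound 1 to compound 4 cannot be read, and how far either compound lies past the limit stays unresolved: the limit of > 10000 nM in this assay, at which 2 of the 4 values shown sit. Still open is whether the piperidine ring or the aminoethyl amide chain accounts for the rise, which an unsubstituted piperidin-1-yl group or a 3-hydroxypropylamino group at this place could help to separate.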